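Aryl tail variation in the iminosugar series

This account rests on a few compounds, and the source may have more. Where it says the series, first, only, none or still open, it means among the compounds named here.

Compound 1 `COc1ccccc1-c1ccc(COCCCCCN2C[C@H](O)[C@@H](O)[C@H](O)[C@H]2CO)cc1` is the reference point of the set. For the measured compounds named here, in an assay on isolated protein for inhibition of Beta-glucosidase (Homo sapiens) (a lower number here means a stronger inhibitor, a higher number a weaker inhibitor), compound 1 gives 3 nM, the lowest of the two numbers measured so far. Compound 2 `OC[C@@H]1[C@@H](O)[C@H](O)[C@@H](O)CN1CCCCCOCc1ccc(-c2cc(C(F)(F)F)cc(C(F)(F)F)c2)cc1`, which carries a different terminal aryl group on the same core, gives 15 nM in this assay, a gap from compound 1 that lies beyond the usual scatter. Going by the values given here, no single-point step between measured compounds is available, so any expectation for a new terminal aryl rests on these two values alone.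

Compound 3 `OC[C@@H]1[C@@H](O)[C@H](O)[C@@H](O)CN1CCCCCOCc1ccc(-c2ccc(F)nc2)cc1` is the next candidate for this assay. Relative to compound 1 the change is confined to the terminal ring: 6-fluoropyridin-3-yl in place of 2-methoxyphenyl on an aromatic carbon. With compound 2 showing that a changed terminal aryl still gives 15 nM, a modest upward step from compound 1 to compound 3 is expected, of about a 3.0-fold higher number from compound 1 to compound 3 (0.48 log units; beyond the scatter), possibly no more than the scatter. Compound 3 is estimated at 9 nM in this assay, with a plausible range from 3 nM to 30 nM.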

Compound 3, half-maximal inhibitory concentration: 5 nM
Estimate against measurement, compound 3: 1.8-fold (0.26 log units) above, and the stated range covers the measured number.
By their numbers in this assay, from the lowest: compounds 1 and 3 (each within the scatter of the next); then compound 2.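

In this assay, for the compounds shown here, the step of a 1.7-fold higher number from compound 1 to compound 3 (0.22 log units; within the scatter) gives the first comparison that differs in one place only, and it concerns the terminal ring on an aromatic carbon, para to a large group. Replacing 2-methoxyphenyl with 6-fluoropyridin-3-yl, a six-membered aromatic ring of carbon only giving way to one with a hetero atom, therefore leaves the number within the scatter on the shared core, while the different terminal aryl of compound 2 stands at 15 nM. No measurement in hand accounts for this result, so it stands as an observation without an explanation.

The ring nitrogen and the fluorine enter together and the methoxy group leaves in the same step, so the contribution of each cannot be separated from these compounds. Open questions are what an unsubstituted pyridin-3-yl, a 6-methoxypyridin-3-yl or a terminal phenyl bearing a carboxylic acid would give at this position, and whether the step stays this small with a longer chain on the shared core.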